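From compound 2 to compound 3: a methyl step

A few compounds are considered here, and "the series" means these few. Any claim that something is new, unique, unknown or untested is made for them only; others in the source may bear on it.

Measured so far in a functional assay on A549 cells (Homo sapiens) for inhibition, read by sulforhodamine B assay (on this read-out higher numbers stand for weaker inhibition of growth and lower numbers for stronger inhibition of growth), are two compounds:
- compound 1 `c1ccc(-c2ccc(-c3ccc(-c4nc5ccccc5[nH]4)cc3)cc2)cc1` with 41200 nM as its number
- compound 2 `FC(F)(F)Oc1ccc(-c2ccc(-c3ccc(-c4nc5ccccc5[nH]4)cc3)cc2)cc1` with 38000 nM as its number

Going by the values given here, compound 2 is one of only two compounds with a number in this assay and stands level with compound 1 within the scatter. Among the compounds with values here, the one measured step is a 1.1-fold lower number from compound 1 to compound 2 (0.04 log units; within the scatter) and it comes from trifluoromethoxy in place of hydrogen on an aromatic carbon. Compound 3 `Cc1ccc2[nH]c(-c3ccc(-c4ccc(-c5ccc(OC(F)(F)F)cc5)cc4)cc3)nc2c1` is compound 2 with methyl in place of hydrogen on an aromatic carbon and it has not yet been measured. Within the data shown here, no measured step involves a methyl, so the evidence is indirect. Among the measured compounds shown here, the single step from compound 1 to compound 2 only shows that a much larger substituent left the number within the scatter. A similarly small change is therefore expected here, with no direction favoured. The estimate means a 1.1-fold lower number from compound 2 to compound 3 (0.02 log units; within the scatter) and this is expected to stay within the scatter. Compound 3 is estimated at 36000 nM in this assay with an expected range from 17000 nM to 70000 nM for its measurement.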

Compound 3, concentration for 50% growth inhibition: 3560 nM
The estimate for compound 3 lay 10-fold (1.00 log units) above the measured number; measured number outside the range, below it.
By their numbers in this assay, from the lowest: compound 3; then compounds 2 and 1 (each within the scatter of the next).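

Until now, the only step in this assay was the trifluoromethoxy change, and a 1.1-fold lower number from compound 1 to compound 2 (0.04 log units; within the scatter) stayed within the scatter, so the compounds shown gave no sign that a single substituent could move the number. The change from 1H-benzimidazol-2-yl to 5-methyl-1H-benzimidazol-2-yl shows otherwise: adding one carbon, as a methyl on an aromatic carbon of the six-membered aromatic ring of carbon only, gives an 11-fold lower number from compound 2 to compound 3 (1.03 log units; beyond the scatter) and is a large step beyond the scatter, which makes this place the first shown where a small change matters in this assay. Nothing measured here accounts for the size of this step.

The compounds shown leave open whether the gain is particular to methyl or would also appear with a longer chain such as ethyl, with a chlorine, or with an amine on the same carbon. They also leave open whether methyl would give a step of similar size on compound 1, which lacks the trifluoromethoxy group, so it cannot yet be said whether the two changes act independently.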